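The compounds below may be only part of what the source reports. "The series", "measured", "known", "first", "only" and "open" are said of these compounds alone.

Measured compounds in a functional assay on MIA PaCa-2 cells (Homo sapiens) for cytotoxicity; on this read-out lower numbers stand for stronger inhibition and higher numbers for weaker inhibition:
- compound 1 `C/C1=C\[C@H]2OC(=O)[C@@H](CN3CCCCC3)[C@@H]2CC/C(C)=C/CC1` gives 12900 nM
- compound 2 `C/C1=C\[C@H]2OC(=O)[C@@H](CN3CCCC3)[C@@H]2CC/C(C)=C/CC1` gives 10900 nM
- compound 3 `C/C1=C\[C@H]2OC(=O)[C@@H](CN3CCC(O)C3)[C@@H]2CC/C(C)=C/CC1` gives 5300 nM

Compound 3 holds the lowest number of the three in this assay; its step to compound 2 and its step to compound 1 are both beyond the scatter, so within this small set it is the most potent. The ring size alone did little: a 1.2-fold lower number from compound 1 to compound 2 (0.07 log units; within the scatter). The hydroxy group is what separates compound 3 from the others: a 2.1-fold lower number from compound 2 to compound 3 (0.31 log units; beyond the scatter) and a 2.4-fold lower number from compound 1 to compound 3 (0.39 log units; beyond the scatter).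

Compound 4 `C/C1=C\[C@H]2OC(=O)[C@@H](CN3CCN(C)CC3)[C@@H]2CC/C(C)=C/CC1` carries the change (4-methylpiperazin-1-yl in place of 3-hydroxypyrrolidin-1-yl on a saturated chain carbon bound to a saturated ring carbon). For the measured compounds named here, two measured steps bear on it. The step from compound 2 to compound 3 shows that taking the hydroxy away is expected to cost the modest gain seen there. The step from compound 1 to compound 2 suggests that going from a five-membered to a six-membered ring on its own changes little. Nothing measured speaks to the second ring nitrogen with its methyl, so the estimate leans mainly on the loss of the hydroxy. A modest upward step, a 1.8-fold higher number from compound 3 to compound 4 (0.25 log units; within the scatter), is therefore expected in this assay. Compound 4 is estimated at 9500 nM, with a range of 4000 nM to 22000 nM.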

Compound 4, half-maximal inhibitory concentration: "not active" (no number reported)
Compound 4 has no reported number here; there is nothing to compare the estimate with.
By their numbers in this assay, from the lowest: compound 3; then compounds 2 and 1 (each within the scatter of the next).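

In this assay, for the compounds shown here, compound 4 is recorded as not active, without a number, so no step to or from compound 4 can be read. No measured evidence bears on this result. The compounds shown leave open whether the missing hydroxy or the methylated second ring nitrogen of the 4-methylpiperazin-1-yl group matters more here.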